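A branched chain replaces pentyl in compound 4

The source may report more compounds than this note shows. Statements on the series, on what has been measured and on what is new or still open speak of the compounds shown alone.

Within the data shown here, in an assay on CHO cells for antagonist activity at transient receptor potential cation channel subfamily V member 1 (Homo sapiens), read by FLIPR and calcium flux (on this read-out higher numbers stand for weaker inhibition and lower numbers for stronger inhibition), compound 3 `CCCCCc1nc(C(F)(F)F)ccc1CNC(=O)C(C)c1ccc(NS(C)(=O)=O)c(F)c1` gives 1 nM, the second highest of the three numbers measured so far: compound 1 `CC(C(=O)NCc1ccc(C(F)(F)F)nc1Cl)c1ccc(NS(C)(=O)=O)c(F)c1` gives 0.2 nM, and compound 2 `CCCc1nc(C(F)(F)F)ccc1CNC(=O)C(C)c1ccc(NS(C)(=O)=O)c(F)c1` gives 22.7 nM. Compound 4 `CC(C(=O)NCc1ccc(C(F)(F)F)nc1CCC(C)(C)C)c1ccc(NS(C)(=O)=O)c(F)c1` differs from compound 3 by tert-butyl in place of propyl on a saturated chain carbon, two bonds along the chain from an aromatic carbon. The nearest measured step is a 23-fold lower number from compound 2 to compound 3 (1.36 log units; beyond the scatter), a large lowering when the chain grows longer; a 5.0-fold higher number from compound 1 to compound 3 (0.70 log units; beyond the scatter) and a 110-fold higher number from compound 1 to compound 2 (2.05 log units; beyond the scatter) set the chains against chloro. Among the measured compounds shown here, no measured step tests a branched chain of similar length, so the forecast rests on compound 3 alone. Compound 4 is expected to show a 1.5-fold higher number from compound 3 to compound 4 (0.18 log units; within the scatter), not beyond the scatter. The estimate for compound 4 is 1.5 nM, within 0.4 nM to 6 nM.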

Compound 4, inhibition constant: 0.6 nM
Beside the measured number, compound 4's estimate is 2.5-fold (0.40 log units) above it; measured number inside the range.
By their numbers in this assay, from the lowest: compound 1; then compounds 4 and 3 (each within the scatter of the next); then compound 2.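

In this assay, the chain tolerates branching at its far end: 3,3-dimethylbutyl in place of pentyl gives a 1.7-fold lower number from compound 3 to compound 4 (0.22 log units; within the scatter). The large gain over the shorter chain survives this branching, with a 38-fold lower number from compound 2 to compound 4 (1.58 log units; beyond the scatter), while chloro still keeps an edge, with a 3.0-fold higher number from compound 1 to compound 4 (0.48 log units; beyond the scatter). No supporting data explain these differences. From the compounds shown here alone, whether a chain longer than 3,3-dimethylbutyl would close the remaining gap to chloro stays open. So does the effect of an amine or a carboxylic acid at the end of the chain.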